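The source may hold more compounds than are shown below. What is called first, only, known or untested is meant among the compounds shown, and "the series" means these compounds.

The measured compounds:
Compound 1, `O=C(O)[C@@H]1CCCN1C(=O)/C=C/c1ccncc1-c1ccc2ccccc2c1`, gives 67% in an assay on a protein complex for inhibition of CDK8/Cyclin C (Homo sapiens), with a stated time of 1 h, tested at 10 uM; on this read-out higher numbers stand for more inhibition at the one concentration tested (going by the name of the read-out) and lower numbers for less inhibition.
Compound 2, `NNC(=O)CCc1ccncc1-c1ccc2ccccc2c1`, gives 102% in this assay.
Compound 3, `O=C(/C=C/c1ccncc1-c1ccc2[nH]ccc2c1)N1CCOCC1`, gives 97% in this assay.

Compound 2 has the highest of the three numbers. Compound 3 lies a short way lower, within the usual scatter of repeated measurements, so the two cannot be told apart on this read-out. Compound 1 lies well below compound 2, a gap beyond the scatter.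

Compound 4, `NNC(=O)COc1ccncc1-c1ccc2ccccc2c1`, has not yet been measured in this assay. It differs from compound 2 in one place: (aminocarbamoyl)methoxy in place of 2-(aminocarbamoyl)ethyl on an aromatic carbon. For the measured compounds named here, the shared core is kept; only this side group changes. Going by the values given here, no measured pair here differs in just this way, so there is no step between measured compounds to lean on. Because compound 2 reads 102%, close to the top of what this read-out can show, there is little room upward, and a modest loss is the more likely direction, though a result within the scatter of compound 2 would not surprise.

Compound 4 is expected to give 85% in this assay, with a range from 55% to 105%. That estimate means an expected step of a number 17 percentage points lower from compound 2 to compound 4 (beyond the scatter), a small drop.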

Compound 4, a percentage reported as inhibition, at one concentration (the size of the read-out at that concentration, not a potency): 19%
For compound 4 the middle estimate is 66 percentage points above the measured one; the measured number lies below the stated range.
By their numbers in this assay, from the lowest: compound 4; then compound 1; then compounds 3 and 2 (each within the scatter of the next).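

In this assay, placing (aminocarbamoyl)methoxy instead of 2-(aminocarbamoyl)ethyl on this aromatic carbon, ortho to a large group and opposite the ring nitrogen, gives a number 83 percentage points lower from compound 2 to compound 4 (beyond the scatter). The two groups match in heavy-atom count and hydrogen-bond donors, and neither contains a ring; the entering group has one oxygen in place of one carbon and one more hydrogen-bond acceptor, so the read-out at this position can change greatly with a very small change in atoms. Nothing available explains why this swap has so large an effect.

The compounds shown leave open whether the loss is tied to the oxygen itself or would also appear with another atom in that place, as in an amine-linked group such as (aminocarbamoyl)methylamino. They also leave open how a longer chain, such as 3-(aminocarbamoyl)propyl, would read at this position, and whether the same oxygen-for-carbon change would have a similar effect on a different core.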